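Replacing the thiophen-2-yl of compound 2 with 2-bromophenyl

The compounds below may be only part of what the source reports. "The series", "measured", "known", "first", "only" and "open" are said of these compounds alone.

Going by the values given here, compound 2 `O=C1N=C(N2CCC[C@H]2C(=O)Nc2ccc3ncnc(Nc4cccc(Cl)c4)c3c2)S/C1=C/c1cccs1` gives 6100 nM in a functional assay on A549 cells (Homo sapiens) for antiproliferative activity, read by MTT assay; a higher number here means a weaker inhibitor, a lower number a stronger inhibitor; this is the only numeric value in the pair. Compound 1 `O=C1N=C(N2CCC[C@H]2C(=O)Nc2ccc3ncnc(Nc4cccc(Cl)c4)c3c2)S/C1=C/c1ccc(Br)s1` differs from compound 2 by a bromo on an aromatic carbon. In this assay compound 1 stops at the limit > 50000 nM. The step from that limit is an at least 8.1-fold lower number from compound 1 to compound 2 (0.91 log units; beyond the scatter), and the limit of > 50000 nM in this assay, at which 1 of the 2 values shown sits, is the bound behind it.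

Compound 3 `O=C1N=C(N2CCC[C@H]2C(=O)Nc2ccc3ncnc(Nc4cccc(Cl)c4)c3c2)S/C1=C/c1ccccc1Br` remains unmeasured. Its change from compound 2 is 2-bromophenyl in place of thiophen-2-yl on a double-bonded chain carbon bound to a double-bonded ring carbon. Among the compounds with values here, no measured pair covers the exchange of a thiophen-2-yl for a six-membered carbon ring, so that part of the change has no precedent here. Within the data shown here, the one step bearing on it is an at least 8.1-fold lower number from compound 1 to compound 2 (0.91 log units; beyond the scatter), in which the loss of a bromo on an aromatic carbon gave a step of at least modest size towards a lower number. Compound 3 reintroduces a bromo, now on the 2-bromophenyl, so a step back towards a higher number is expected, a 3.3-fold higher number from compound 2 to compound 3 (0.52 log units; beyond the scatter), with a real chance that only a limit is reported. Compound 3 is estimated at 20000 nM, with a range from 6000 nM to 60000 nM.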

Compound 3, half-maximal inhibitory concentration: > 50000 nM
Compound 3 gave a limit, no number (the forecaster's own chance of this, stated with the estimate: 35%); middle value at least 2.5-fold (0.39 log units) from the limit.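

The exchange of thiophen-2-yl for 2-bromophenyl on a double-bonded chain carbon bound to a double-bonded ring carbon gives an at least 8.1-fold higher number from compound 2 to compound 3 (0.91 log units; beyond the scatter), so this position tolerates a change of the ring itself no better than the addition of a bromo to the thiophen-2-yl. Across the three compounds, both that carry a bromo on this aromatic ring lose a measurable value and the one without it keeps a number, with no compound going against this, although compound 3 changes the ring and adds the bromo in a single step, so neither change can be credited with the loss alone. Compound 1 and compound 3 both stop at a limit, the step between them cannot be read, and any ranking of the two stays hidden: the limit of > 50000 nM in this assay, at which 2 of the 3 values shown sit.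

The compounds shown leave open whether a plain phenyl, without the bromo, would keep a number in this assay, which would separate the ring exchange from the bromo. Also open, on these data alone, is whether an amine or a carboxylic acid in the place of the bromo on the thiophen-2-yl would follow hydrogen or bromo.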